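Removing Chloro from an Allyloxy Pyridyl Ketone

This account rests on a few compounds, and the source may have more. Where it says the series, first, only, none or still open, it means among the compounds named here.

Measured so far:
- compound 1 `O=C(c1cccnc1)c1ccccc1O` gives 33400 nM
- compound 2 `O=C(c1cccnc1)c1cccc(Cl)c1O` gives 31500 nM
- compound 3 `C=CCOc1ccc(Cl)cc1C(=O)c1cccnc1` reaches only a limit of the assay, > 100000 nM

These values come from a functional assay on PC-3 cells (Homo sapiens) for cytotoxicity, read by sulforhodamine B assay, with a stated time of 48 h; on this read-out lower numbers stand for stronger inhibition and higher numbers for weaker inhibition. Between compound 2 and compound 1 the change is hydrogen in place of chloro on an aromatic carbon, and it produced a 1.1-fold higher number from compound 2 to compound 1 (0.03 log units; within the scatter). For compound 3 the read-out is a limit, not a number, the line at the limit of > 100000 nM in this assay, at which 1 of the 3 values shown sits.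

Compound 4 `C=CCOc1ccccc1C(=O)c1cccnc1` is not yet measured. It differs from compound 3 by hydrogen in place of chloro on an aromatic carbon. This is the same kind of change as from compound 2 to compound 1, but the surroundings are not identical: in compound 2 the chloro sits ortho to a hydroxy group, whereas in compound 3 it sits para to an allyloxy group. How the core of compound 2 and the core of compound 3 differ is not broken down here.

Since the earlier step stayed within the scatter, a similarly small step is expected from compound 3 to compound 4, namely a step that the limit leaves unreadable from compound 3 to compound 4. Compound 4 is therefore expected to give about 150000 nM, within 60000 nM to 400000 nM, most likely again reported only as a limit.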

Compound 4, half-maximal inhibitory concentration: 55000 nM
The estimate for compound 4 lay 2.7-fold (0.44 log units) above the measured number; measured number below the stated range.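

Hydrogen in place of chloro gives an at least 1.8-fold lower number from compound 3 to compound 4 (0.25 log units; that floor lies within the scatter), while allyl in place of hydrogen on the oxygen, with no chloro present, gives a 1.6-fold higher number from compound 1 to compound 4 (0.22 log units; within the scatter). As far as these compounds go, compound 3 has only a limit, > 100000 nM, not a number, so the first of these steps is a floor and its true size stays unknown. The chloro change can therefore be set beside its earlier counterpart, but it cannot be shown to carry over unchanged from one core to the other, nor to behave differently there: the same change on two cores in this assay, a 1.1-fold higher number (0.03 log units; within the scatter) from compound 2 to compound 1 and an at least 1.8-fold lower number (0.25 log units; that floor lies within the scatter) from compound 3 to compound 4; the limit leaves it open whether they differ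

The compounds shown leave open whether a group other than chloro, such as fluoro or nitrile, would give a different result at the same place on the ring. They also leave open what a longer chain or an amine-bearing chain would do on the oxygen in place of allyl.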